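Removing a Branched Alkyl Group on the Shared Core

A few compounds are considered here, and "the series" means these few. Any claim that something is new, unique, unknown or untested is made for them only; others in the source may bear on it.

Measured compounds:
compound 1: `CC[C@@H](C(=O)N[C@@H](CC(=O)O)C(=O)CSCc1ccccc1)n1cccc(NC(=O)[C@H](CC(=O)O)NC(C)=O)c1=O` — 220 nM
compound 2: `CCCCCCN(C)CNCC(=O)[C@H](CC(=O)O)NC(=O)C(CC)n1cc(C(C)(CC)CC)nc(NCc2nonc2C)c1=O` — > 10000 nM

In an assay for inhibition of Caspase-8 (Homo sapiens) (on this read-out higher numbers stand for weaker inhibition and lower numbers for stronger inhibition), compound 1 gives 220 nM. Compound 2 stands differently: in this assay compound 2 reaches only > 10000 nM, and this is a limit of the assay, not a number. Within the data shown here, the two compounds share no single-point change, so their values can only be set side by side, and no step between them is given.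

Compound 3, `CCCCCCN(C)CNCC(=O)[C@H](CC(=O)O)NC(=O)C(CC)n1ccnc(NCc2nonc2C)c1=O`, is not yet measured. It differs from compound 2 in one place: hydrogen in place of 1-ethyl-1-methylpropyl on an aromatic carbon. Because compound 2 sits at the limit of > 10000 nM in this assay, at which 1 of the 2 values shown sits, the size of the expected step from compound 2 to compound 3 cannot be anchored to a number. The account expects a step of a number no higher from compound 2 to compound 3 (the limit leaves the size open), if any, with compound 3 likely remaining near the limit. For compound 3 the estimated value is 10000 nM, within a range from 3000 nM to 30000 nM.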

Compound 3, half-maximal inhibitory concentration: > 10000 nM
Compound 3 ended at the assay's limit; the forecaster's own chance of this, stated with the estimate: 70%; the middle value lies on the limit itself.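

Compound 2 and compound 3 both stand at a limit of the assay rather than at a number, so no step can be read from one to the other: the limit of > 10000 nM in this assay, at which 2 of the 3 values shown sit.

The compounds shown leave open whether hydrogen in place of 1-ethyl-1-methylpropyl changes inhibition at all.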